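This account rests on a few compounds, and the source may have more. Where it says the series, first, only, none or still open, it means among the compounds named here.

Compounds measured so far:

- Compound 1, `CC(C)C(Nc1nnc[nH]1)c1ccc(-c2ccc3cccc(F)c3c2)[nH]c1=O`: 22 nM
- Compound 2, `CCn1ncc2c(F)cc(-c3ccc(C(CC)(CC)c4nnc[nH]4)c(=O)[nH]3)cc21`: 17 nM
- Compound 3, `CC(C)C(Cc1nnc[nH]1)c1ccc(-c2ccc3cccc(F)c3c2)[nH]c1=O`: 10 nM

All three were tested in an assay on CHO cells for displacement of a labelled ligand from prostaglandin E2 receptor EP3 subtype (Homo sapiens), read by radioligand binding; on this read-out lower numbers stand for stronger inhibition and higher numbers for weaker inhibition. Compound 3 shows the lowest of the three numbers; its gap to compound 2 is within the usual scatter, while its gap to compound 1 is beyond it. Among the compounds with values here, the one measured step that involves compound 3 is a 2.2-fold lower number from compound 1 to compound 3 (0.34 log units; beyond the scatter), a modest gain when the amino link to the triazole was exchanged for a methylene link.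

Compound 4, `CC(C)C(c1nnc[nH]1)c1ccc(-c2ccc3cccc(F)c3c2)[nH]c1=O`, takes this same spot one step further: 4H-1,2,4-triazol-3-yl in place of (4H-1,2,4-triazol-3-yl)methyl on a saturated chain carbon bound to an aromatic carbon and a saturated chain carbon. The triazole ring is kept, but the carbon that joined it to the chain is gone, so the ring now sits directly on the saturated chain carbon. Within the data shown here, no measured pair shows exactly this change. Among the measured compounds shown here, the only guide is that varying the link at this position, from compound 1 to compound 3, moved the number by a modest amount, so a shift of similar size in either direction, or none beyond the scatter, is the reasonable expectation for this assay. Compound 4 is therefore estimated at 15 nM, with a range from 5 nM to 50 nM, which corresponds to an expected step of a 1.5-fold higher number from compound 3 to compound 4 (0.18 log units; within the scatter).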

Compound 4, inhibition constant: 12 nM
For compound 4 the middle estimate is 1.3-fold (0.10 log units) above the measured one, and the stated range covers the measured number.
By their numbers in this assay, from the lowest: compounds 3, 4, 2 and 1 (each within the scatter of the next, the first and the last beyond it).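

Removing the carbon that joined the triazole to the chain, so that the ring sits directly on the saturated chain carbon, gives a 1.2-fold higher number from compound 3 to compound 4 (0.08 log units; within the scatter) in this assay. The direct attachment also stands close to the amino link, with a 1.8-fold lower number from compound 1 to compound 4 (0.26 log units; within the scatter), so of the three links shown, only a 2.2-fold lower number from compound 1 to compound 3 (0.34 log units; beyond the scatter) lies beyond the scatter, and that step is modest. Within these three compounds, then, the triazole can be attached directly, through an amino link or through a methylene link with little effect on the number, and nothing shown here explains why the link matters so little.

Still open, on these data alone, is what a longer chain between the saturated chain carbon and the triazole would do, or what would follow from replacing the triazole with a carboxylic acid or an amine, since every link compared here carries the same ring. As far as these compounds go, compound 2 has a different core and differs from the others in more than one place, so whether the direct attachment behaves the same way on other cores also remains open.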